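Methyl on the linker carbon of the thiophene analogue

A few compounds are considered here, and "the series" means these few. Any claim that something is new, unique, unknown or untested is made for them only; others in the source may bear on it.

Three compounds share a core in which a propanoic acid on a phenyl ring carries an ether-linked oxadiazole bearing an aromatic group. Compound 1 `O=C(O)CCc1ccc(OCc2nc(-c3ccccc3Cl)no2)cc1` gives 1200 nM in a functional assay on CHO cells for agonist activity at Free fatty acid receptor 1 (Homo sapiens), read by FLIPR and calcium flux, in the presence of a further agent that is not named here (on this read-out higher numbers stand for an effect only at larger amounts of compound and lower numbers for an effect already at smaller amounts), compound 2 `O=C(O)CCc1ccc(OCc2nc(-c3cccc(Br)c3)no2)cc1` gives 1260 nM, and compound 3 `O=C(O)CCc1ccc(OCc2nc(-c3cccs3)no2)cc1` gives 2570 nM. Compound 3 stands with the highest number of the three: the step of a 2.1-fold higher number from compound 1 to compound 3 (0.33 log units; beyond the scatter) and the step of a 2.0-fold higher number from compound 2 to compound 3 (0.31 log units; beyond the scatter) both lie beyond the scatter, while a 1.1-fold higher number from compound 1 to compound 2 (0.02 log units; within the scatter) lies within it.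

Compound 4 `CC(Oc1ccc(CCC(=O)O)cc1)c1nc(-c2cccs2)no1` differs from compound 3 by methyl in place of hydrogen on a saturated chain carbon bound to an aromatic carbon and an oxygen on an aromatic ring. Among the measured compounds shown here, none of the measured steps touches this position; all three concern the aromatic group on the oxadiazole, so they give no direct guidance on the size or direction of the change. With nothing in the series to anchor it, the expectation for compound 4 is a number close to that of compound 3, with a wide range to cover either direction, estimated as 1800 nM between 600 nM and 5500 nM. This estimate means a step of a 1.4-fold lower number from compound 3 to compound 4 (0.15 log units; within the scatter), expected to remain within the scatter.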

Compound 4, half-maximal effective concentration: 4000 nM
Compound 4: the middle estimate sits 2.2-fold (0.35 log units) below what was measured, and the stated range covers the measured number.
By their numbers in this assay, from the lowest: compounds 1 and 2 (each within the scatter of the next); then compounds 3 and 4 (each within the scatter of the next).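

In this assay this is the only change shown at the saturated chain carbon bound to an aromatic carbon and an oxygen on an aromatic ring, as the earlier steps all exchange 2-chlorophenyl, 3-bromophenyl and thiophen-2-yl. Methyl in place of hydrogen there gives a 1.6-fold higher number from compound 3 to compound 4 (0.19 log units; within the scatter), so with thiophen-2-yl in the structure this carbon carries the added methyl with no step beyond the scatter. No evidence is available on what lies behind this step.

Still open, on these data alone, is whether the same methyl reads alike with 2-chlorophenyl or 3-bromophenyl in place of thiophen-2-yl. Also open, as far as these compounds go, is how an ethyl, a hydroxyl or an amine on this carbon would read, since one methyl says nothing about other groups there.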